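Moving the Methyl on the Chlorophenyl Ring of Compound 3

A few compounds are considered here, and "the series" means these few. Any claim that something is new, unique, unknown or untested is made for them only; others in the source may bear on it.

In an assay on HEK293 cells for displacement of a labelled ligand from Melanocortin receptor 4 (Homo sapiens) (a higher number here means a weaker inhibitor, a lower number a stronger inhibitor), three compounds have been measured:
Compound 1 `CC(C)C[C@H](N)c1cc(C(F)(F)F)ccc1N1CCN(C(=O)COc2cccc(Cl)c2Cl)CC1` gives 2500 nM
Compound 2 `CC(C)C[C@H](N)c1cc(C(F)(F)F)ccc1N1CCN(C(=O)COc2cccc(Cl)c2)CC1` gives 2600 nM
Compound 3 `Cc1cc(CC(C)C(=O)N2CCN(c3ccc(C(F)(F)F)cc3[C@@H](N)CC(C)C)CC2)ccc1Cl` gives 71 nM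

Compound 3 has the lowest number of the three, and the steps leading to it, a 35-fold lower number from compound 1 to compound 3 (1.55 log units; beyond the scatter) and a 37-fold lower number from compound 2 to compound 3 (1.56 log units; beyond the scatter), are both large and beyond the scatter. Compound 4 `Cc1cc(Cl)ccc1CC(C)C(=O)N1CCN(c2ccc(C(F)(F)F)cc2[C@@H](N)CC(C)C)CC1` differs from compound 3 only by 4-chloro-2-methylphenyl in place of 4-chloro-3-methylphenyl on a saturated chain carbon, two bonds along the chain from a carbonyl carbon. Among the compounds with values here, no measured step shifts a methyl around this ring; the two large steps exchange the whole acyl side chain and bear only loosely on so small a rearrangement. The expectation is therefore a step of a 1.7-fold higher number from compound 3 to compound 4 (0.23 log units; within the scatter) in this assay, close to the scatter. Compound 4 is expected to give 120 nM, estimated between 30 nM and 500 nM.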

Compound 4, inhibition constant: 38 nM
The estimate for compound 4 lay 3.2-fold (0.50 log units) above the measured number; low and high end bracket the measured number.
By their numbers in this assay, from the lowest: compounds 4 and 3 (each within the scatter of the next); then compounds 1 and 2 (each within the scatter of the next).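

In this assay, moving the methyl to give 4-chloro-2-methylphenyl in place of 4-chloro-3-methylphenyl is a 1.9-fold lower number from compound 3 to compound 4 (0.27 log units; within the scatter), so the ring bears this shift without a change that can be told from the scatter. The large steps away from the phenoxy side chains persist with the new ring, at a 68-fold lower number from compound 2 to compound 4 (1.84 log units; beyond the scatter) and a 66-fold lower number from compound 1 to compound 4 (1.82 log units; beyond the scatter). Nothing in the data shown offers an explanation for these numbers. The compounds shown leave open how a methoxy or a fluoro group would behave in place of this methyl, and whether the ring needs the methyl at all.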